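The source may hold more compounds than are shown below. What is called first, only, known or untested is meant among the compounds shown, and "the series" means these compounds.

For the measured compounds named here, only two compounds have numbers so far in an ADME assay on Caco-2 cells (Homo sapiens) for permeability (on this read-out higher numbers stand for higher permeability and lower numbers for lower permeability), and those numbers sit close together. Compound 1 (`O=C(C[C@H]1CC(=O)c2c(F)cc(F)cc21)N[C@@H]1O[C@H](CO)[C@@H](O)[C@H](O)[C@H]1O`) gives 31.7 nm/s and compound 2 (`COC(=O)c1ccc(/C=C/C(=O)N[C@@H]2O[C@H](CO)[C@@H](O)[C@H](O)[C@H]2O)cc1`) gives 26.3 nm/s on this read-out, so the two lie within the usual scatter of each other. Going by the values given here, compound 2 therefore stands level with the only other measured compound, and neither is set apart.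

Compound 3 (`CC(C)c1ccc(/C=C/C(=O)N[C@@H]2O[C@H](CO)[C@@H](O)[C@H](O)[C@H]2O)cc1`) has isopropyl in place of methoxycarbonyl on an aromatic carbon, para to a large group (isopropyl in place of methoxycarbonyl on an aromatic carbon). Among the compounds with values here, no measured pair isolates this change, so the data offer no direct step to lean on. Within the data shown here, the only guide is that compound 1 at 31.7 nm/s and compound 2 at 26.3 nm/s lie together although their structures differ outside the shared core. On that slender ground, only a small upward step is expected in this assay. The estimated step is a 1.4-fold higher number from compound 2 to compound 3 (0.14 log units; within the scatter) and it is expected to stay within the scatter. For compound 3 the expected value is 36 nm/s with an estimated range of 14 nm/s to 90 nm/s as the likely span.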

Compound 3, apparent permeability in the Caco-2 assay: 98.5 nm/s
Compound 3: middle estimate off by 2.7-fold (0.44 log units), on the low side; the whole stated range lies below it.
By their numbers in the Caco-2 assay, from the lowest: compounds 2 and 1 (each within the scatter of the next); then compound 3.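

The aromatic carbon para to a large group proves to be a place where the Caco-2 assay responds: with isopropyl in place of methoxycarbonyl, the read-out shows a 3.7-fold higher number from compound 2 to compound 3 (0.57 log units; beyond the scatter). The earlier compounds shown here could not show this, since they differ outside the shared core and no single change could be read from them; their closeness therefore said nothing about this position. In a physicochemical assay for lipophilicity, measured as octanol-water partition (a higher number here means a more lipophilic compound, a lower number a more polar compound), compound 2 gives -0.805 and compound 3 gives 0.296. The same swap removes the hydrogen-bond acceptors of the methoxycarbonyl group, and the higher permeability may be due to the accompanying gain in lipophilicity, although this one pair cannot separate the two and offers only a single point for any such link: the measured partition coefficient of compound 2, -0.805, and of compound 3, 0.296, a number 1.10 log units higher (beyond the scatter).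

The compounds shown leave open whether the read-out would follow lipophilicity with other groups on this aromatic carbon, such as trifluoromethyl, chlorine, a carboxylic acid, an amine or a longer alkyl chain. They also leave open whether isopropyl in place of methoxycarbonyl would give a step of similar size on a different core.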